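From Hydroxy to Fluoro on a Shared Core

This account rests on a few compounds, and the source may have more. Where it says the series, first, only, none or still open, it means among the compounds named here.

In an ADME assay on RAW264.7 cells (Mus musculus) for cytotoxicity, read by MTT assay (a lower number here means a stronger inhibitor, a higher number a weaker inhibitor), compound 1 `O=C(/C=C/C=C/c1ccccc1)c1ccc(F)cc1` has "not determined" (no result reported) and so offers no comparison. Compound 2 `CN(C)c1ccc(/C=C/C=C/C(=O)c2ccc(F)cc2)cc1` gives > 100000 nM and this is a limit of the assay, not a number. Compound 3 `O=C(/C=C/C=C/c1ccc(O)cc1)c1ccc(O)cc1` gives > 100000 nM and this too is a limit, not a number. Compound 3 therefore stands at the limit of > 100000 nM in this assay, at which 2 of the 3 values shown sit, and has no exact position of its own.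

Compound 4 `O=C(/C=C/C=C/c1ccc(O)cc1)c1ccc(F)cc1` differs from compound 3 in one place: fluoro in place of hydroxy on an aromatic carbon with fluoro in place of hydroxy on an aromatic carbon. Within the data shown here, no measured pair shows what this swap does. Compound 2 also carries a fluoro group and its > 100000 nM is again a limit. A change beyond the usual scatter is therefore not expected in either direction, and this assay may well report only a limit for compound 4 too. The estimated step of a number no higher from compound 3 to compound 4 (the limit leaves the size open) is accordingly small. For compound 4 the expected value is 100000 nM with an estimated range from 30000 nM to 300000 nM in this reading.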

Compound 4, half-maximal inhibitory concentration: 45500 nM
The estimate for compound 4 lay 2.2-fold (0.34 log units) above the measured number, and the stated range covers the measured number.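

In this assay, fluoro in place of hydroxy on an aromatic carbon, para to a large group, brings an at least 2.1-fold lower number from compound 3 to compound 4 (0.34 log units; beyond the scatter), the first sign among these compounds that a change at this position can move the read-out beyond the scatter. Hydroxy in place of dimethylamino on an aromatic carbon brings an at least 2.1-fold lower number from compound 2 to compound 4 (0.34 log units; beyond the scatter), so a second single change arriving at compound 4 also gives a lower number. Both steps give only a minimum size, because each starts from a compound that reports a limit and not a number: the limit of > 100000 nM in this assay, at which 2 of the 4 values shown sit.

On these data alone, the true size of either step remains unknown, and one pair for each change cannot show whether the same swap would act alike on another core. As far as these compounds go, how a carboxylic acid or a methoxy group at this position would read in this assay also remains open.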